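A few compounds are considered here, and "the series" means these few. Any claim that something is new, unique, unknown or untested is made for them only; others in the source may bear on it.

Measured so far:
compound 1, `Cc1cccc(C)c1OC(C)C1=NCCN1` — in a functional assay on CHO cells for agonist activity at Alpha-2C adrenergic receptor (Homo sapiens) (a higher number here means that more compound is needed for the effect, a lower number that less compound is needed), compound 1 gives 27.5 nM
compound 2, `CC(Oc1ccccc1Br)C1=NCCN1` — in this assay compound 2 gives 10 nM

Of the two numbers, compound 2 has the lower one; compound 1 lies beyond the scatter above it. Compound 3, `CC(Oc1ccccc1S(C)(=O)=O)C1=NCCN1`, has not yet been measured. It differs from compound 2 in one place: methylsulfonyl in place of bromo on an aromatic carbon. Within the data shown here, no measured pair shows this kind of change, so the size of the step is uncertain. Because the bromo of compound 2 gives 10 nM and nothing here shows a methylsulfonyl, a loss is expected, and the step of a 10-fold higher number from compound 2 to compound 3 (1.00 log units; beyond the scatter) is the estimate. Compound 3 is expected to give about 100 nM, between 20 nM and 600 nM.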

Compound 3, half-maximal effective concentration: 316 nM
Compound 3: the middle estimate sits 3.2-fold (0.50 log units) below what was measured; the measured number falls inside the stated range.
By their numbers in this assay, from the lowest: compound 2; then compound 1; then compound 3.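

In this assay, putting methylsulfonyl in place of bromo on this aromatic carbon gives a 32-fold higher number from compound 2 to compound 3 (1.50 log units; beyond the scatter) and shows that this position does not take every group equally well. The change is large, and much more compound is needed for the same effect. The entering group differs from bromo in several ways at once, and nothing measured here tells which of them matters. On these data alone, how the number would move with a chlorine, a methoxy or an amine at this place remains open. As far as these compounds go, whether methylsulfonyl costs as much on the core of compound 1 is also open.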